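One more methoxy on compound 3

The source may report more compounds than this note shows. Statements on the series, on what has been measured and on what is new or still open speak of the compounds shown alone.

Compound 1 `COc1ccc(/C=C/C(=O)c2ccc(OCC=C(C)C)cc2O)cc1OC`: > 100000 nM, a limit of the assay
Compound 2 `COc1cc(/C=C/C(=O)c2ccc(OCC=C(C)C)cc2O)cc(OC)c1OC`: 81000 nM
Compound 3 `COc1ccc(/C=C/C(=O)c2ccc(OCC=C(C)C)cc2OCC=C(C)C)cc1OC`: 66500 nM

In a functional assay on MCF7 cells (Homo sapiens) for cytotoxicity, read by MTT assay, with a stated time of 24 h (a higher number here means a weaker inhibitor of growth, a lower number a stronger inhibitor of growth), compound 3 gives 66500 nM and compound 2 gives 81000 nM, two values within the scatter of each other. Compound 1 stands only at a limit of the assay. Compound 4 `COc1cc(/C=C/C(=O)c2ccc(OCC=C(C)C)cc2OCC=C(C)C)cc(OC)c1OC` differs from compound 3 by methoxy in place of hydrogen on an aromatic carbon. The same change appears in the step of an at least 1.2-fold lower number from compound 1 to compound 2 (0.09 log units; that floor lies within the scatter), which starts from a limit and so gives only a floor. The step of an at least 1.5-fold lower number from compound 1 to compound 3 (0.17 log units; that floor lies within the scatter) is a different change and also gives only a floor. No shift beyond the scatter is therefore expected in this assay. The expected step is a 1.2-fold lower number from compound 3 to compound 4 (0.08 log units; within the scatter). Compound 4 is estimated at 55000 nM, with an expected range of 28000 nM to 100000 nM.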

Compound 4, concentration for 50% growth inhibition: 9000 nM
Estimate against measurement, compound 4: 6.1-fold (0.79 log units) above, and the stated range ends above it.
By their numbers in this assay, from the lowest: compound 4; then compounds 3 and 2 (each within the scatter of the next). At a limit, above all of these: compound 1.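

In this assay, methoxy in place of hydrogen at this place on the ring, ortho to a methoxy group, gives a 7.4-fold lower number from compound 3 to compound 4 (0.87 log units; beyond the scatter), a step of this change that is more than a floor. The 3-methylbut-2-en-1-yl in place of hydrogen on an oxygen on an aromatic ring likewise gives a 9.0-fold lower number from compound 2 to compound 4 (0.95 log units; beyond the scatter), so each change shows its size when the other is present. Whether the methoxy step depends on the core stays unsettled: the same change on two cores in this assay, an at least 1.2-fold lower number (0.09 log units; that floor lies within the scatter) from compound 1 to compound 2 and a 7.4-fold lower number (0.87 log units; beyond the scatter) from compound 3 to compound 4; the limit leaves it open whether they differ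

The compounds shown leave open whether an amine or an ethoxy group at this place would give a step of similar size. They also leave open how a longer chain on that oxygen would compare with 3-methylbut-2-en-1-yl.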